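Chloro in place of methoxy on compound 1

The source may report more compounds than this note shows. Statements on the series, on what has been measured and on what is new or still open speak of the compounds shown alone.

For the measured compounds named here, compound 1 (`COc1ccc(NC(=S)NC2CC(C)(C)Oc3ccc(Br)cc32)cc1`) gives 33000 nM in a functional assay on T98G cells (Homo sapiens) for inhibition, read by MTT assay, with a stated time of 72 h (on this read-out higher numbers stand for weaker inhibition and lower numbers for stronger inhibition), the only actual number so far. Compound 2 (`CCNC(=S)NC1CC(C)(C)Oc2ccc(Cl)cc21`) reads > 100000 nM in this assay, which is a limit of the assay and not a number. Going by the values given here, compound 1 therefore has no measured neighbour to be ranked against, and no step between measured compounds is available as a guide.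

Compound 3 (`CC1(C)CC(NC(=S)Nc2ccc(Cl)cc2)c2cc(Br)ccc2O1`) has not yet been measured. It differs from compound 1 at one place, with chloro in place of methoxy on an aromatic carbon, para to a large group, so that 4-methoxyphenyl becomes 4-chlorophenyl: chloro in place of methoxy on an aromatic carbon. The rest of the structure is unchanged.

Among the compounds with values here, with no measured example of this exchange, the expectation rests on the value of compound 1, 33000 nM, and on the modest size of the change. The expected result is a 1.7-fold lower number from compound 1 to compound 3 (0.22 log units; within the scatter), a small shift towards stronger inhibition that stays within the usual scatter. For compound 3 the estimated value is 20000 nM, with an expected range of 7000 nM to 60000 nM.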

Compound 3, half-maximal inhibitory concentration: 22000 nM
The estimate for compound 3 lay 1.1-fold (0.04 log units) below the measured number; the measured number falls inside the stated range.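

In this assay, the change from 4-methoxyphenyl to 4-chlorophenyl gives the series its first readable step between two measured compounds: a 1.5-fold lower number from compound 1 to compound 3 (0.18 log units; within the scatter). At this position para to a large group, methoxy and chloro therefore cannot be told apart in this assay, even though the exchange removes the hydrogen-bond acceptor of methoxy and replaces two heavy atoms with one. Compound 2 stays a limit of the assay and not a number, and no step connects it with the other compounds: the limit of > 100000 nM in this assay, at which 1 of the 3 values shown sits.

A single exchange at this position does not show whether an amine, a carboxylic acid or a longer chain such as butoxy on the same aromatic carbon would move the number beyond the scatter. It also leaves open whether chloro in place of methoxy would read the same way on a core other than that of compound 1, and whether any change at the thiourea or on the shared core would matter more than this one.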